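Replacing a Difluorophenyl Group with Thiophenyl: Expecting No Gain

This account rests on a few compounds, and the source may have more. Where it says the series, first, only, none or still open, it means among the compounds named here.

Compound 1 `CC(C)(C)Cc1c(-c2cccc(F)c2F)sc(N)c1C(=O)c1ccc(Cl)cc1` was tested in an assay on CHO cells for displacement of a labelled ligand from adenosine receptor A1 (Homo sapiens), read by scintillation counting, tested at 10 uM (a higher number here means more inhibition at the concentration tested (going by the name of the read-out), a lower number less inhibition), and gave 1%. Compound 2 `CC(C)(C)Cc1c(Br)sc(N)c1C(=O)c1cccc(Cl)c1` gave 1% in this assay, and compound 3 `CC(C)(C)Cc1c(-c2ccccc2)sc(N)c1C(=O)c1ccc(Cl)cc1Cl` gave 1%. On these numbers compound 1 sits level with compounds 2 and 3 at the digits shown; its nearest neighbour is compound 2 and its furthest is compound 3, with no change at the digits shown in either case, both within the usual scatter. Compound 4 `CC(C)(C)Cc1c(-c2cccs2)sc(N)c1C(=O)c1ccc(Cl)cc1` differs from compound 1 by one change: thiophen-2-yl in place of 2,3-difluorophenyl on an aromatic carbon. For the measured compounds named here, no step between two measured compounds is available, so there is no measured guide for this change. Because compound 1 gives only 1%, the step of a number 1 percentage points higher from compound 1 to compound 4 (within the scatter) is expected to be small, none beyond the scatter. Compound 4 is expected to give 2%, within a range from 0% to 12%.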

Compound 4, a percentage reported as inhibition, at one concentration (the size of the read-out at that concentration, not a potency): 1%
The estimate for compound 4 lay 1 percentage points above the measured number; measured number inside the range.
By their numbers in this assay, from the lowest: compounds 1, 2, 3 and 4 (each within the scatter of the next).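

In this assay, for the compounds shown here, thiophen-2-yl in place of 2,3-difluorophenyl next to the ring sulfur gives no change at the digits printed from compound 1 to compound 4 (within the scatter) and is the first step read at this position. A five-membered aromatic ring with one sulfur and a six-membered all-carbon ring thus give the same reading here, but with both so close to zero, this step cannot show whether either group matters. No measurement here offers an explanation for this result. Still open, from the compounds shown here alone, is whether an amine or a carboxylic acid at this position would raise the inhibition above the scatter.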